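Swapping chloro for methyl on the pendant aryl ring

A few compounds are considered here, and "the series" means these few. Any claim that something is new, unique, unknown or untested is made for them only; others in the source may bear on it.

Compound 1: `Cc1cccc(-c2cc(O)c3cc(C)cnc3n2)c1` — 251 nM
Compound 2: `Cc1cnc2[nH]c(-c3cccc(F)c3)cc(=O)c2c1` — 13.5 nM
Compound 3: `Cc1ccc2c(O)cc(-c3cccc(Cl)c3)nc2n1` — < 10 nM

Of the compounds shown here, three have been measured in a functional assay on OVCAR-3 cells (Homo sapiens) for antiproliferative activity; on this read-out higher numbers stand for weaker inhibition of growth and lower numbers for stronger inhibition of growth. Compound 1 gives 251 nM and compound 2 gives 13.5 nM. For compound 3 the result is only a limit of the assay, < 10 nM, so its true potency is not pinned to a number; compound 3 sits at the limit of < 10 nM in this assay, at which 1 of the 3 values shown sits, the strongest end of the range observed so far.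

Compound 4, `Cc1cccc(-c2cc(O)c3ccc(C)nc3n2)c1`, shares the core of compound 3 and differs from it by methyl in place of chloro on an aromatic carbon. Going by the values given here, no pair of measured compounds differing in a single place is available to calibrate this change, so the expected size of the step rests on the overall spread of values and on the fact that compound 3 is only known as a limit. The change is expected to cost some potency, with a step from the limit of compound 3 of about an at least 1.8-fold higher number from compound 3 to compound 4 (0.25 log units; that floor lies within the scatter) in this assay, though a result within the usual scatter of compound 3 cannot be ruled out. Compound 4 is therefore estimated at 18 nM in this assay, within a range of 5 nM to 70 nM.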

Compound 4, concentration for 50% growth inhibition: 490 nM
For compound 4 the middle estimate is 27-fold (1.43 log units) below the measured one; measured number above the stated range.
By their numbers in this assay, from the lowest: compound 2; then compounds 1 and 4 (each within the scatter of the next). At a limit, below all of these: compound 3.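

Going by these compounds alone, this is the first comparison in the set between two compounds that differ in only one place, and it shows that the group on this aromatic carbon, meta to a large group, matters strongly for growth inhibition. In this assay, methyl in place of chloro gives an at least 49-fold higher number from compound 3 to compound 4 (1.69 log units; beyond the scatter). Compound 3 is known only as a limit of the assay, < 10 nM, so the true step may be larger than the printed one: the limit of < 10 nM in this assay, at which 1 of the 4 values shown sits.

The compounds shown leave open whether the loss follows from chloro leaving or from methyl entering, and how a bromo, a methoxy or a nitrile at this place would read. They also leave open whether a change of this size would recur with the core's methyl placed as in compound 1.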